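A few compounds are considered here, and "the series" means these few. Any claim that something is new, unique, unknown or untested is made for them only; others in the source may bear on it.

Working notes on the series. Compound 1 `CCN(c1ccc(C#N)c(Cl)c1)c1cc(-c2ccccc2)ccc1C` sits at the limit of a functional assay on CWR22R cells (Homo sapiens) for antiproliferative activity, read by CCK-8 assay, with a stated time of 6 days (a higher number here means a weaker inhibitor, a lower number a stronger inhibitor), and gives > 30000 nM. Compound 2 `CCN(c1ccc(C#N)c(Cl)c1)c1cc(-n2cccn2)ccc1C` also gives only a limit in this assay, > 30000 nM. Among the compounds with values here, compound 3 `CCN(c1ccc(C#N)c(Cl)c1)c1cc(-c2c[nH]nc2C)ccc1C` is the one compound with a number in this assay, 5380 nM, and stands apart on that count. Compounds 1 and 2 sit at the limit (the limit of > 30000 nM in this assay, at which 2 of the 3 values shown sit). The steps of an at least 5.5-fold lower number from compound 1 to compound 3 (0.74 log units; beyond the scatter) and an at least 5.5-fold lower number from compound 2 to compound 3 (0.74 log units; beyond the scatter) show that the group at this position matters. Compound 4 `CCN(c1ccc(C#N)c(Cl)c1)c1cc(-c2ccncc2)ccc1C` differs from compound 3 by pyridin-4-yl in place of 3-methyl-1H-pyrazol-4-yl on an aromatic carbon. Within the data shown here, the entering ring has the six-membered ring of compound 1 and the single acceptor of compound 2, without the donor of compound 3, so a weaker inhibitor is expected, with a 4.1-fold higher number from compound 3 to compound 4 (0.61 log units; beyond the scatter). Compound 4 is estimated at 22000 nM, between 7000 nM and 40000 nM, with a real chance the assay again reports only a limit.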

Compound 4, half-maximal inhibitory concentration: 1030 nM
Beside the measured number, compound 4's estimate is 21-fold (1.33 log units) above it; the whole stated range lies above it.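

In this assay, a hydrogen-bond donor on this ring is not required: pyridin-4-yl has none, yet the change gives a 5.2-fold lower number from compound 3 to compound 4 (0.72 log units; beyond the scatter). A six-membered ring is also not excluded, as the single ring nitrogen gives an at least 29-fold lower number from compound 1 to compound 4 (1.46 log units; beyond the scatter). The step to the same compound from the other limit-bound compound, an at least 29-fold lower number from compound 2 to compound 4 (1.46 log units; beyond the scatter), shows that a hydrogen-bond acceptor alone does not decide the outcome, and both of these large steps are bounds: the limit of > 30000 nM in this assay, at which 2 of the 4 values shown sit.

Still open, going by these compounds, is whether pyridin-3-yl would keep this gain. Also open, on these data alone, is whether an amine or a methyl group on the pyridin-4-yl ring would lower the number further.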